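Hydrazone aryl swap on a shared oxadiazole core

A few compounds are considered here, and "the series" means these few. Any claim that something is new, unique, unknown or untested is made for them only; others in the source may bear on it.

Compound 1 `COc1ccccc1-c1nnc(-c2ccc(C(=O)N/N=C/c3ccc(F)cc3)cc2)o1`: 427000 nM
Compound 2 `COc1ccccc1-c1nnc(-c2ccc(C(=O)N/N=C/c3ccc(O)cc3O)cc2)o1`: 104000 nM

In an ADME assay on THP-1 cells (Homo sapiens) for cytotoxicity (on this read-out lower numbers stand for stronger inhibition and higher numbers for weaker inhibition), compound 2 gives the lowest of the two numbers; compound 1 sits a 4.1-fold lower number from compound 1 to compound 2 (0.61 log units; beyond the scatter) away, a step beyond the scatter. Compound 3 `COc1ccc(/C=N/NC(=O)c2ccc(-c3nnc(-c4ccccc4OC)o3)cc2)cc1O` differs from compound 2 only at the hydrazone end: 3-hydroxy-4-methoxyphenyl in place of 2,4-dihydroxyphenyl on a carbon with a double bond to nitrogen. Going by the values given here, the only step measured, from compound 1 to compound 2, also changed this aryl group and was modest, so a similar-sized or smaller step is expected here, probably toward a higher number, estimated at a 1.7-fold higher number from compound 2 to compound 3 (0.24 log units; within the scatter). In this assay compound 3 is therefore expected to give about 180000 nM, with a range from 80000 nM to 400000 nM.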

Compound 3, half-maximal inhibitory concentration: 260000 nM
Beside the measured number, compound 3's estimate is 1.4-fold (0.16 log units) below it; the measured number falls inside the stated range.
By their numbers in this assay, from the lowest: compound 2; then compounds 3 and 1 (each within the scatter of the next).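

In this assay, moving between two hydroxy-bearing aryl groups at this position still matters: there is a 2.5-fold higher number from compound 2 to compound 3 (0.40 log units; beyond the scatter), so carrying a hydroxy group does not by itself give the lowest number. Against 4-fluorophenyl there is a 1.6-fold lower number from compound 1 to compound 3 (0.22 log units; within the scatter), which leaves these two compounds within the scatter of each other. Nothing available explains the difference between these aryl groups. Still open, as far as these compounds go, is what an amine or a carboxylic acid on this aryl ring would do to the number.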